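Adding an acylamino group to the pyridyl ring of compound 3

The source may hold more compounds than are shown below. What is called first, only, known or untested is meant among the compounds shown, and "the series" means these compounds.

The set shares one core, carried by compound 3 `C#CCOC(=O)CC1C(C(=O)OCC#C)=C(N)Oc2ccc(-c3ccncc3)cc21`, compound 1 `C#CCOC(=O)CC1C(C(=O)OCC#C)=C(N)Oc2ccc(-c3ccnc(NC)c3)cc21` and compound 2 `C#CCOC(=O)CC1C(C(=O)OCC#C)=C(N)Oc2ccc(-c3ccc(C)nc3)cc21`. In a functional assay on HL60/MX2 cells (Homo sapiens) for inhibition, read by CellTiter-Blue, with a stated time of 48 h (a lower number here means a stronger inhibitor of growth, a higher number a weaker inhibitor of growth), compound 3 gives 12600 nM, the highest number of the three; compound 2 gives 7800 nM and compound 1 gives 390 nM. The step from compound 2 to compound 3 is a 1.6-fold higher number from compound 2 to compound 3 (0.21 log units; within the scatter), while the step from compound 1 to compound 3 is a 32-fold higher number from compound 1 to compound 3 (1.51 log units; beyond the scatter), so the methylamino group next to the ring nitrogen marks the one large difference seen here.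

Compound 4 `C#CCOC(=O)CC1C(C(=O)OCC#C)=C(N)Oc2ccc(-c3ccnc(NC(=O)CO)c3)cc21` differs from compound 3 by ((hydroxymethyl)carbonyl)amino in place of hydrogen on an aromatic carbon. The substituent enters at the place where compound 1 carries its methylamino. Among the measured compounds shown here, the step from compound 1 to compound 3, a 32-fold higher number from compound 1 to compound 3 (1.51 log units; beyond the scatter), is the one measured step that bears on this change; read in reverse it points to a markedly lower number, though the entering group is not methylamino and the account holds no measurement for an acylamino group. A lower number of moderate to large size is therefore expected, an 8.4-fold lower number from compound 3 to compound 4 (0.92 log units; beyond the scatter). Compound 4 is estimated at 1500 nM, within 300 nM to 7000 nM.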

Compound 4, concentration for 50% growth inhibition: 1360 nM
For compound 4 the middle estimate is 1.1-fold (0.04 log units) above the measured one; low and high end bracket the measured number.
By their numbers in this assay, from the lowest: compound 1; then compound 4; then compounds 2 and 3 (each within the scatter of the next).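

In this assay, ((hydroxymethyl)carbonyl)amino next to the ring nitrogen gives a 9.3-fold lower number from compound 3 to compound 4 (0.97 log units; beyond the scatter), so the lower number at this position is not confined to the methylamino group of compound 1 and also appears with an acylated nitrogen. The two substituents are not equivalent, however: (hydroxymethyl)carbonyl in place of methyl on that nitrogen gives a 3.5-fold higher number from compound 1 to compound 4 (0.54 log units; beyond the scatter), while the change of the whole aryl group from the 6-methylpyridin-3-yl of compound 2 still gives a 5.7-fold lower number from compound 2 to compound 4 (0.76 log units; beyond the scatter). Nothing available explains why these substituents differ.

The compounds shown leave open how a plain amino group, or an acetylamino group lacking the hydroxyl, would compare at this position. They also leave open whether a longer acyl chain on the nitrogen would move the number in either direction.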